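Swapping Nitro for Methylsulfanyl on the Aryl Ring

The compounds below may be only part of what the source reports. "The series", "measured", "known", "first", "only" and "open" are said of these compounds alone.

Of the compounds shown here, three share a common core and have been tested in a functional assay on A549 cells (Homo sapiens) for antiproliferative activity, read by MTT assay, with a stated time of 48 h; on this read-out lower numbers stand for stronger inhibition and higher numbers for weaker inhibition. Compound 1 `COc1cc(C(=O)/C=C/c2cn(C)c3ccccc23)cc(SC)c1OC` gives 188 nM in this assay. Compound 2 `COc1ccc2c(/C=C/C(=O)c3cc(OC)c(OC)c(SC)c3)c[nH]c2c1` gives 115 nM. Compound 3 `COc1cc(C(=O)/C=C/c2c[nH]c3ccccc23)cc([N+](=O)[O-])c1OC` gives 1510 nM, the highest of the three numbers: its gap to compound 1 and its gap to compound 2 both lie beyond the usual scatter of such measurements, so compound 3 is the weakest inhibitor of the set.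

Compound 4 `COc1cc(C(=O)/C=C/c2c[nH]c3ccccc23)cc(SC)c1OC` has not yet been measured. It differs from compound 3 in one place: methylsulfanyl in place of nitro on an aromatic carbon

Compound 3 carries a nitro group at this position and gives the weakest result, while compound 1 and compound 2, which both carry methylsulfanyl at the same position on the aryl ring, give much lower numbers. The change from compound 3 to compound 4 is expected to bring the number down substantially, well beyond the scatter, as an 8.4-fold lower number from compound 3 to compound 4 (0.92 log units; beyond the scatter). Compound 4 is therefore estimated to give about 180 nM in this assay, most likely between 60 nM and 550 nM.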

Compound 4, half-maximal inhibitory concentration: 152 nM
The estimate for compound 4 lay 1.2-fold (0.07 log units) above the measured number; the measured number falls inside the stated range.
By their numbers in this assay, from the lowest: compounds 2, 4 and 1 (each within the scatter of the next); then compound 3.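

For the compounds shown here, with only this one place changed, the swap of nitro for methylsulfanyl gives a 9.9-fold lower number from compound 3 to compound 4 (1.00 log units; beyond the scatter) in this assay, so the gap between compound 3 and the other compounds can now be tied to this group on this aromatic carbon; the earlier comparisons, each differing in more than one place, could not show that. The other two changes leave the number within the scatter: hydrogen in place of methoxy on an aromatic carbon gives a 1.3-fold higher number from compound 2 to compound 4 (0.12 log units; within the scatter), and hydrogen in place of methyl on the aromatic nitrogen gives a 1.2-fold lower number from compound 1 to compound 4 (0.09 log units; within the scatter), so neither the methoxy nor the methyl is needed for a low number here. Nothing available explains why the swap at this position has so large an effect.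

Going by these compounds alone, only two groups are compared at this position, so it remains open whether methylsulfanyl itself matters or whether an amine, a chlorine atom or a longer chain such as ethylsulfanyl would serve as well. As far as these compounds go, whether the same step holds on other cell types also remains open.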